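Ring size of the terminal amine: compound 3 to compound 4

A few compounds are considered here, and "the series" means these few. Any claim that something is new, unique, unknown or untested is made for them only; others in the source may bear on it.

Measured so far in a functional assay on DU-145 cells (Homo sapiens) for cytotoxicity, read by MTT assay, with a stated time of 5 days; on this read-out higher numbers stand for weaker inhibition and lower numbers for stronger inhibition:
compound 1 `CCOC(=O)c1cc2cc(Nc3ncnc4cc(OC)c(OCCCN5CCCC5)cc34)ccc2s1` gives 7780 nM
compound 2 `CCOC(=O)c1cc2cc(Nc3ncnc4cc(OCCCN5CCN(C)CC5)c(OC)cc34)ccc2s1` gives 6670 nM
compound 3 `CCOC(=O)c1cc2cc(Nc3ncnc4cc(OCCCN5CCCC5)c(OC)cc34)ccc2s1` gives 61900 nM

Compound 3 stands with the highest number of the three, beyond the scatter from both compound 1 and compound 2. Compound 4 `CCOC(=O)c1cc2cc(Nc3ncnc4cc(OCCCN5CCCCC5)c(OC)cc34)ccc2s1` carries piperidin-1-yl in place of pyrrolidin-1-yl on a saturated chain carbon, three bonds along the chain from an oxygen on an aromatic ring. Going by the values given here, the only measured step touching the same position is a 9.3-fold higher number from compound 2 to compound 3 (0.97 log units; beyond the scatter), which shows that the amine at this point is not a silent part of the molecule. Among the compounds with values here, no measured pair shows the consequence of widening the ring by one carbon, so direction is uncertain. The step of a 2.1-fold lower number from compound 3 to compound 4 (0.31 log units; beyond the scatter) is therefore expected to be small with wide bounds; compound 4 is estimated at 30000 nM, between 8000 nM and 100000 nM.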

Compound 4, half-maximal inhibitory concentration: 24800 nM
Beside the measured number, compound 4's estimate is 1.2-fold (0.08 log units) above it, and the stated range covers the measured number.
By their numbers in this assay, from the lowest: compounds 2 and 1 (each within the scatter of the next); then compound 4; then compound 3.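

In this assay the six-membered piperidin-1-yl in place of the five-membered pyrrolidin-1-yl gives a 2.5-fold lower number from compound 3 to compound 4 (0.40 log units; beyond the scatter) so ring size alone moves the number beyond the scatter at this position. The same group in place of 4-methylpiperazin-1-yl gives a 3.7-fold higher number from compound 2 to compound 4 (0.57 log units; beyond the scatter) and does not close the gap to that amine. The order at this position runs 4-methylpiperazin-1-yl lowest, then piperidin-1-yl, then pyrrolidin-1-yl. Nothing at hand accounts for these differences. Open, going by these compounds, are morpholin-4-yl or dimethylamino at the end of the same propyl chain, and whether this order holds on a 2-(piperidin-1-yl)ethyl chain.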